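Replacing a Cyclohexyl Group with a Second Aryl Ring

The source may hold more compounds than are shown below. What is called first, only, known or untested is meant among the compounds shown, and "the series" means these compounds.

Measured compounds:
Compound 1 `CC(C)(C)[C@H]1CC[C@H](c2cc(-c3ccc(OC(F)(F)F)cc3)nn2Cc2ccc(C(=O)NCCC(=O)O)cc2)CC1` gives 480 nM.
Compound 2 `O=C(O)CCNC(=O)c1ccc(Cn2nc(-c3ccc(OC(F)(F)F)cc3)cc2C2CCCCC2)cc1` gives 3800 nM.

For the measured compounds named here, in an assay on CHO cells for displacement of a labelled ligand from Glucagon receptor (Homo sapiens) (on this read-out lower numbers stand for stronger inhibition and higher numbers for weaker inhibition), compound 2 stands at the higher of the two numbers, with compound 1 as its only neighbour, a 7.9-fold higher number from compound 1 to compound 2 (0.90 log units; beyond the scatter). Compound 3 `O=C(O)CCNC(=O)c1ccc(Cn2nc(-c3ccc(OC(F)(F)F)cc3)cc2-c2ccc(OC(F)(F)F)cc2)cc1` differs from compound 2 by 4-(trifluoromethoxy)phenyl in place of cyclohexyl on an aromatic carbon. Going by the values given here, the single measured step concerns a tert-butyl on the cyclohexyl that now leaves, so no measured step bears directly on this exchange. Compound 3 is therefore estimated near the measured range, at 1500 nM (from 300 nM to 8000 nM), which would mean an expected 2.5-fold lower number from compound 2 to compound 3 (0.40 log units; beyond the scatter).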

Compound 3, half-maximal inhibitory concentration: 490 nM
For compound 3 the middle estimate is 3.1-fold (0.49 log units) above the measured one, and the stated range covers the measured number.
By their numbers in this assay, from the lowest: compounds 1 and 3 (each within the scatter of the next); then compound 2.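

This position accepts an aromatic ring as well as a saturated one: in this assay, 4-(trifluoromethoxy)phenyl in place of cyclohexyl gives a 7.8-fold lower number from compound 2 to compound 3 (0.89 log units; beyond the scatter). Adding tert-butyl to the cyclohexyl was not the only way to recover the number, since exchanging 4-(tert-butyl)cyclohexyl for 4-(trifluoromethoxy)phenyl gives a 1.0-fold higher number from compound 1 to compound 3 (0.01 log units; within the scatter). No supporting data explain this match between two different groups. As far as these compounds go, it remains open whether the ring or its trifluoromethoxy group accounts for the step, which a plain phenyl ring here could help separate.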